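A few compounds are considered here, and "the series" means these few. Any claim that something is new, unique, unknown or untested is made for them only; others in the source may bear on it.

Compound 1 `CC(C)=CCOc1cc(Nc2ncccn2)ccc1C`: 78000 nM
Compound 2 `CSc1ccnc(Nc2ccc(Cl)c(OCC=C(C)C)c2)n1`: 2800 nM
Compound 3 `COc1ccnc(Nc2ccc(Cl)c(OCC=C(C)C)c2)n1`: 9000 nM

In a functional assay on MT2 cells (Homo sapiens) for cytotoxicity, read by MTT assay (a lower number here means that less compound is tolerated, a higher number that more compound is tolerated), compound 3 stands second highest of the three numbers, below compound 1 and above compound 2, from which it is separated by a 3.2-fold higher number from compound 2 to compound 3 (0.51 log units; beyond the scatter). Compound 4 `COc1ccnc(Nc2ccc(C)c(OCC=C(C)C)c2)n1` differs from compound 3 by methyl in place of chloro on an aromatic carbon. Within the data shown here, no measured step bears directly on this change: the only step on record, a 3.2-fold higher number from compound 2 to compound 3 (0.51 log units; beyond the scatter), concerns a different group, and compound 1, the one other compound carrying the methyl, gives 78000 nM but also differs from compound 3 in its core, so its value points only loosely toward a higher number. The expected step in this assay is therefore a 1.7-fold higher number from compound 3 to compound 4 (0.22 log units; within the scatter), a modest rise at most. Compound 4 is estimated at 15000 nM, with a range of 6000 nM to 40000 nM.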

Compound 4, half-maximal cytotoxic concentration: 41000 nM
For compound 4 the middle estimate is 2.7-fold (0.44 log units) below the measured one, and the stated range ends below it.
By their numbers in this assay, from the lowest: compound 2; then compound 3; then compounds 4 and 1 (each within the scatter of the next).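

In this assay, chloro to methyl on the aromatic carbon ortho to the (3-methylbut-2-en-1-yl)oxy group now has a direct reading: a 4.6-fold higher number from compound 3 to compound 4 (0.66 log units; beyond the scatter). With methyl at this place, methoxy in place of hydrogen on an aromatic carbon gives a 1.9-fold lower number from compound 1 to compound 4 (0.28 log units; within the scatter), so that change does not separate the pair beyond the scatter. Nothing available accounts for the effect of chloro to methyl.

From the compounds shown here alone, whether fluoro or ethyl at this place would track chloro or methyl remains open. So does whether methylsulfanyl to methoxy would give a comparable step with methyl in place of chloro.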